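Chloro for fluoro on a shared imidazopyrazine series

The source may hold more compounds than are shown below. What is called first, only, known or untested is meant among the compounds shown, and "the series" means these compounds.

The measured compounds, with their values in an ADME assay on Vero cells (Chlorocebus sabaeus) for cytotoxicity, read by MTT assay; a higher number here means that more compound is tolerated, a lower number that less compound is tolerated:

Compound 1, `COc1cc(Nc2c(-c3ccc(Cl)cc3)nc3cnccn23)cc(OC)c1OC`, gives 32000 nM.
Compound 2, `COc1cc(Nc2c(-c3ccc(F)cc3)nc3cnccn23)cc(OC)c1OC`, gives 48000 nM.
Compound 3, `COc1ccc(Nc2c(-c3ccc(F)cc3)nc3cnccn23)cc1`, gives 72000 nM.

Compound 1 and compound 2 share one core and differ only in the halogen on the pendant ring: chloro in place of fluoro on an aromatic carbon. In this assay this gave a 1.5-fold lower number from compound 2 to compound 1 (0.18 log units; within the scatter), so the two values cannot be told apart.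

Compound 3 carries a different core, and the difference between the two cores is not broken down here. Its value in this assay is the highest of the three numbers, but it sits within the scatter of compound 2 and only beyond it against compound 1.

Compound 4, `COc1ccc(Nc2c(-c3ccc(Cl)cc3)nc3cnccn23)cc1`, has not been measured. It stands to compound 3 exactly as compound 1 stands to compound 2: chloro in place of fluoro on an aromatic carbon. The place lines of the two changes read the same word for word, so this is the same change, seen a second time on a different core.

Going by the values given here, for compound 4 a step of about a 1.5-fold lower number from compound 3 to compound 4 (0.18 log units; within the scatter) is expected, resting on the single earlier instance of this change, a 1.5-fold lower number from compound 2 to compound 1 (0.18 log units; within the scatter), which was within the scatter. On that basis compound 4 is estimated at 48000 nM in this assay, with a likely range from 24000 nM to 100000 nM.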

Compound 4, concentration lethal to 50% of the cells: 45000 nM
Compound 4: middle estimate off by 1.1-fold (0.03 log units), on the high side, within the range that was stated.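

The new pair gives a 1.6-fold lower number from compound 3 to compound 4 (0.20 log units; within the scatter) in this assay, so the change from 4-fluorophenyl to 4-chlorophenyl has now been read on two cores of this series. Set side by side, the two readings agree, and in these two cases the step carried over from one core to the other without a detectable difference: the same change on two cores in this assay, a 1.5-fold lower number (0.18 log units; within the scatter) from compound 2 to compound 1 and a 1.6-fold lower number (0.20 log units; within the scatter) from compound 3 to compound 4, 1.1-fold (0.03 log units) apart, within the scatter of two such steps. This does not show that chloro in place of fluoro has any real effect on tolerance in either core, since each step on its own lies within the scatter and the two halogens cannot be told apart on either core; nor does agreement on two cores establish a rule for other cores in the series.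

The compounds shown leave open how a bromine atom, a nitrile or a carboxylic acid would read in this assay at the same place on the pendant ring, which carries only fluoro or chloro here. They also leave open whether the step would hold on a core in which an amine or a longer chain stands in place of the methoxy groups.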